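The source may report more compounds than this note shows. Statements on the series, on what has been measured and on what is new or still open speak of the compounds shown alone.

Measured compounds:
Compound 1, `CCCCCCCNC[C@@H]1OC[C@H](N)[C@@H]1O`, in a functional assay on A549 cells (Homo sapiens) for antiproliferative activity, read by MTT assay, with a stated time of 72 h (a lower number here means a stronger inhibitor, a higher number a weaker inhibitor), compound 1 gives > 128000 nM, a limit of the assay and not a number.
Compound 2, `CCCCCCCCCCCNC[C@@H]1OC[C@H](N)[C@@H]1O`, in this assay compound 2 gives 11100 nM.
Compound 3, `CCCCCCCNC[C@@H]1OC[C@H](N)[C@H]1O`, in this assay compound 3 gives > 128000 nM, again a limit of the assay.

Compound 2 differs from compound 1 in one place: butyl in place of hydrogen on a saturated chain carbon, seven bonds along the chain from an amine nitrogen. This change gave an at least 11-fold lower number from compound 1 to compound 2 (1.06 log units; beyond the scatter), a step that starts from a limit, so its true size is known only as a lower bound. Compounds 1 and 3 share all atoms and bonds: the two compounds have the same atoms and bonds and differ only in configuration as drawn: 1 of 3 stereo elements differ; a stereocentre at a saturated ring carbon is drawn S in compound 1 and R in compound 3. Between these two the step is a step that the two limits leave unreadable from compound 1 to compound 3, since both values sit at the same limit, (the limit of > 128000 nM in this assay, at which 2 of the 3 values shown sit), so whether the configuration matters cannot be told from these two, even though the fact that compounds 1 and 3 differ only in the configuration as drawn is the only thing separating them.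

Compound 4, `CCCCCCCCCCCNC[C@@H]1OC[C@H](N)[C@H]1O`, has not yet been measured in this assay. It stands to compound 3 exactly as compound 2 stands to compound 1: butyl in place of hydrogen on a saturated chain carbon, seven bonds along the chain from an amine nitrogen, the same change at the same place. From compound 3 to compound 4 the step is expected to be an at least 8.5-fold lower number from compound 3 to compound 4 (0.93 log units; beyond the scatter), resting on an at least 11-fold lower number from compound 1 to compound 2 (1.06 log units; beyond the scatter) made by the same change on the other configuration of the core, and on the limit at which compound 3 sits. For compound 4 a value of about 15000 nM is expected, with a plausible range from 5000 nM to 90000 nM; there is a fair chance that the assay again returns only a limit.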

Compound 4, half-maximal inhibitory concentration: 9650 nM
For compound 4 the middle estimate is 1.6-fold (0.19 log units) above the measured one, and the stated range covers the measured number.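

In this assay the same change on the second configuration of the core gave an at least 13-fold lower number from compound 3 to compound 4 (1.12 log units; beyond the scatter), so butyl in place of hydrogen at this place on the chain carried over from one core to the other, and the two steps can be set side by side: the same change on two cores in this assay, an at least 11-fold lower number (1.06 log units; beyond the scatter) from compound 1 to compound 2 and an at least 13-fold lower number (1.12 log units; beyond the scatter) from compound 3 to compound 4; the limit leaves it open whether they differ. Each step starts from a limit of the assay, so the compounds show the direction of the change and a lower bound on its size, but not whether it is worth the same on both cores: the limit of > 128000 nM in this assay, at which 2 of the 4 values shown sit. The step between compound 1 and compound 3 cannot be read, whereas with the butyl present the configuration can be compared, and the result is a 1.2-fold lower number from compound 2 to compound 4 (0.06 log units; within the scatter), which gives no sign that this stereocentre matters once the chain carries the butyl: the fact that compounds 2 and 4 differ only in the configuration as drawn.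

The compounds shown leave open whether a longer chain, or a chain ending in an amine or a carboxylic acid, would carry over between the two cores in the same way. They also leave open how the other two stereocentres of the shared core bear on the result.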